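The source may report more compounds than this note shows. Statements on the series, on what has been measured and on what is new or still open speak of the compounds shown alone.

Of the compounds shown here, three built on a shared core have been measured in a functional assay on the whole organism (strain Sprague-Dawley) for inhibition, with Rattus norvegicus as the target, with a stated time of 10 min; on this read-out lower numbers stand for an effect already at smaller amounts and higher numbers for an effect only at larger amounts of compound. Compound 1 `O=C(O)c1cnc(-c2ccccc2F)[nH]c1=O` gives 5 mg/kg, compound 2 `O=C(O)c1cnc(-c2ccccc2Cl)[nH]c1=O` gives 5 mg/kg, and compound 3 `CCCOc1ccccc1-c1ncc(C(=O)O)c(=O)[nH]1` gives 0.9 mg/kg. The step of no change at the digits printed from compound 1 to compound 2 (within the scatter) shows that the two halogen compounds cannot be told apart. By contrast, a 5.6-fold lower number from compound 1 to compound 3 (0.74 log units; beyond the scatter) and a 5.6-fold lower number from compound 2 to compound 3 (0.74 log units; beyond the scatter) set compound 3 apart, so that compound 3 holds the lowest number of the three, with compound 1 and compound 2 both standing beyond the scatter above it.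

Compound 4 `CSc1ccccc1-c1ncc(C(=O)O)c(=O)[nH]1` has not yet been measured. It differs from compound 3 by methylsulfanyl in place of propoxy on an aromatic carbon. The measured steps that bear on this change are a 5.6-fold lower number from compound 1 to compound 3 (0.74 log units; beyond the scatter) and a 5.6-fold lower number from compound 2 to compound 3 (0.74 log units; beyond the scatter), which show that propoxy on the aromatic carbon brought a modest improvement over either halogen. Within the data shown here, no measured step speaks for methylsulfanyl itself, so the account can only place it somewhere between the halogen compounds and compound 3. The expectation for compound 4 is therefore a move back toward the higher numbers, a 2.2-fold higher number from compound 3 to compound 4 (0.35 log units; beyond the scatter), though not necessarily all the way. Compound 4 is thus expected to give 2 mg/kg in this assay, with a range from 0.8 mg/kg to 5 mg/kg.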

Compound 4, dose for 50% inhibition: > 20 mg/kg
Compound 4 gave a limit, no number; the forecaster's own chance of this, stated with the estimate: 5%; middle value at least 10-fold (1.00 log units) away from the limit.
By their numbers in this assay, from the lowest: compound 3; then compounds 1 and 2 (each within the scatter of the next). At a limit, above all of these: compound 4.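

In this assay, among these compounds, the earlier compounds showed this place, on an aromatic carbon ortho to a large group, moving the number in one direction only, with propoxy lower than either halogen; the swap of propoxy for methylsulfanyl now shows that it can also move the number strongly the other way, with an at least 22-fold higher number from compound 3 to compound 4 (1.34 log units; beyond the scatter). Methylsulfanyl does not fall between propoxy and the halogens, but past them, with an at least 4.0-fold higher number from compound 2 to compound 4 (0.60 log units; beyond the scatter) and with an at least 4.0-fold higher number from compound 1 to compound 4 (0.60 log units; beyond the scatter), although the counts of hydrogen-bond donors and acceptors for propoxy and methylsulfanyl are the same. The reading for compound 4 is a limit and not a number: the limit of > 20 mg/kg in this assay, at which 1 of the 4 values shown sits.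

The change from propoxy to methylsulfanyl replaces oxygen with sulfur and shortens the chain in one step, so the compounds shown cannot say which of the two goes with the loss. On these data alone, a methoxy group and a propylsulfanyl group at this place would separate the two, and how far beyond the limit compound 4 really lies also stays open.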